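Piperidinol series: from compound 1 to the unmeasured compound 4

The source may hold more compounds than are shown below. What is called first, only, known or untested is meant among the compounds shown, and "the series" means these compounds.

Measured compounds:
compound 1 `COC(=O)C(c1ccccc1Cl)N1CCC(O)(Cn2cnc3c(cnn3-c3ccc(F)cc3)c2=O)CC1` — "not determined" (no result reported) in an assay on Sf21 cells for inhibition of ubiquitin carboxyl-terminal hydrolase 7 (Homo sapiens), read by spectrophotometry, with stated times of 30 min and 2 h; a lower number here means a stronger inhibitor, a higher number a weaker inhibitor
compound 2 `N#Cc1ccccc1CN1CCC(O)(Cn2cnc3c(cnn3-c3ccc(F)cc3)c2=O)CC1` — 8100 nM
compound 3 `O=c1c2cnn(-c3ccc(F)cc3)c2ncn1CC1(O)CCN(Cc2c(Cl)cccc2Cl)CC1` — "not determined" (no result reported) in this assay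

Compound 1 stands at "not determined" (no result reported) in this assay, so without a single number, and compound 3 likewise stands at "not determined" (no result reported); the only figure available comes from compound 2, which gives 8100 nM in this assay. Compound 4 `COC(=O)c1ccc(CN2CCC(O)(Cn3cnc4c(cnn4-c4ccc(F)cc4)c3=O)CC2)c(Cl)c1` differs from compound 1 in one place: 2-chloro-4-(methoxycarbonyl)benzyl in place of (2-chlorophenyl)(methoxycarbonyl)methyl on an amine nitrogen in a ring. Among the compounds with values here, no measured pair differs in one place, so the size of this step in this assay is not known from the data; it is expected to be modest, without a clear direction beyond the scatter. Compound 4 is estimated at 5000 nM, within 1500 nM to 20000 nM, judged from compound 2 at 8100 nM as the only anchor.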

Compound 4, half-maximal inhibitory concentration: 800 nM
Beside the measured number, compound 4's estimate is 6.3-fold (0.80 log units) above it; the measured number lies below the stated range.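

In this assay the substituent on the amine nitrogen in the ring now has a readable step: 2-chloro-4-(methoxycarbonyl)phenyl in place of 2-cyanophenyl gives a 10-fold lower number from compound 2 to compound 4 (1.01 log units; beyond the scatter) on the shared core. The step from compound 1 to compound 4 cannot be read, as compound 1 has no single number. Nothing measured here accounts for the size of the step.

Going by these compounds, whether the chlorine or the methoxycarbonyl group carries the step remains open. Also open, on these data alone, is how a carboxylic acid or a primary amide would read in place of the methyl ester of compound 4.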